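Nitro in place of cyano: an estimate for compound 4

This account rests on a few compounds, and the source may have more. Where it says the series, first, only, none or still open, it means among the compounds named here.

Three compounds have been measured in a functional assay on A-431 cells (Homo sapiens) for antiproliferative activity, read by CCK-8 assay, with a stated time of 72 h; a higher number here means a weaker inhibitor, a lower number a stronger inhibitor:

Compound 1 `Cc1cc(Nc2cc(N3CCN(C)CC3)nc(Nc3ccc(C#N)cc3)n2)n[nH]1`: 140 nM
Compound 2 `Cc1cc(Nc2cc(N3CCN(C)CC3)nc(Nc3ccc(S(N)(=O)=O)cc3)n2)n[nH]1`: 2760 nM
Compound 3 `COc1ccc(Nc2nc(Nc3cc(C)[nH]n3)cc(N3CCN(C)CC3)n2)cc1`: 385 nM

Compound 1 stands lowest of the three numbers. Its nearest neighbour is compound 3, reached by a 2.8-fold higher number from compound 1 to compound 3 (0.44 log units; beyond the scatter); its furthest is compound 2, reached by a 20-fold higher number from compound 1 to compound 2 (1.29 log units; beyond the scatter). Between those two, a 7.2-fold lower number from compound 2 to compound 3 (0.86 log units; beyond the scatter) is also beyond the scatter.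

Compound 4 `Cc1cc(Nc2cc(N3CCN(C)CC3)nc(Nc3ccc([N+](=O)[O-])cc3)n2)n[nH]1` differs from compound 1 in one place: nitro in place of cyano on an aromatic carbon. Among the measured compounds shown here, no measured step swaps cyano for nitro, so the bearing steps are the three that change the same position on the shared core, one large and two modest. Cyano gave the lowest number among the groups tried there, so a change away from it is more likely to raise the number in this assay than to lower it, but the step is expected to be modest at most. Compound 4 is estimated to give 220 nM, with a range from 70 nM to 700 nM, which means a step of a 1.6-fold higher number from compound 1 to compound 4 (0.20 log units; within the scatter).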

Compound 4, half-maximal inhibitory concentration: 150 nM
Beside the measured number, compound 4's estimate is 1.5-fold (0.17 log units) above it; measured number inside the range.
By their numbers in this assay, from the lowest: compounds 1 and 4 (each within the scatter of the next); then compound 3; then compound 2.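

Nitro proves interchangeable with cyano at this position on the aromatic ring in this assay (a 1.1-fold higher number from compound 1 to compound 4 (0.03 log units; within the scatter)), so cyano no longer stands alone at the low end of the series. Nitro also keeps clear of the other two groups tried there, both methoxy (a 2.6-fold lower number from compound 3 to compound 4 (0.41 log units; beyond the scatter)) and sulfamoyl (an 18-fold lower number from compound 2 to compound 4 (1.26 log units; beyond the scatter)), so compound 3 and compound 2 remain separated from this low pair. Nothing measured here explains why these groups differ or why cyano and nitro read alike.

The compounds shown leave open how other groups at this place would read, such as an amine, a carboxylic acid or trifluoromethyl. They also leave open whether cyano and nitro would still read alike if the other groups on the shared core were changed.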